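Arylamino in place of alkoxy on the enol carbon

A few compounds are considered here, and "the series" means these few. Any claim that something is new, unique, unknown or untested is made for them only; others in the source may bear on it.

Measured so far:
compound 1 `O=C(C1=C(O)C(=O)N(CCCn2ccnc2)C1c1ccc(Br)cc1)c1ccccc1`: 73100 nM
compound 2 `CCCCCOC1=C(C(=O)c2ccccc2)C(c2ccc(Br)cc2)N(CCCn2ccnc2)C1=O`: 7290 nM
compound 3 `NC1=C(C(=O)c2ccccc2)C(c2ccc(Br)cc2)N(CCCn2ccnc2)C1=O`: "not active" (no number reported) (no number)

In a functional assay on A549 cells (Homo sapiens) for antiproliferative activity, read by MTT assay, with a stated time of 72 h (on this read-out higher numbers stand for weaker inhibition and lower numbers for stronger inhibition), compound 2 gives 7290 nM, the lowest number of the two numbers available. Among the measured compounds shown here, its closest measured neighbour is compound 1, which gives 73100 nM; the one measured step, a 10-fold lower number from compound 1 to compound 2 (1.00 log units; beyond the scatter), is beyond the scatter. Compound 3, the free amine on the same carbon, is reported as "not active" (no number reported) without a number.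

Compound 4 `CCOc1ccc(NC2=C(C(=O)c3ccccc3)C(c3ccc(Br)cc3)N(CCCn3ccnc3)C2=O)cc1` differs from compound 2 by (4-ethoxyphenyl)amino in place of pentyloxy on a double-bonded ring carbon. For the measured compounds named here, no measured step covers this exchange: the only step on this carbon, a 10-fold lower number from compound 1 to compound 2 (1.00 log units; beyond the scatter), concerns hydrogen against pentyl on oxygen, and the amine of compound 3 gives no number to scale from. The expectation therefore leans on compound 3 having no reported activity and on compound 2 being the better of the two numbers. For compound 4 a step of a 2.1-fold higher number from compound 2 to compound 4 (0.31 log units; beyond the scatter) towards a weaker number is expected, with wide uncertainty. Compound 4 is estimated at 15000 nM, within 3000 nM to 80000 nM.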

Compound 4, half-maximal inhibitory concentration: 20200 nM
For compound 4 the middle estimate is 1.3-fold (0.13 log units) below the measured one, within the range that was stated.
By their numbers in this assay, from the lowest: compound 2; then compound 4; then compound 1.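

On the double-bonded ring carbon, a 2.8-fold higher number from compound 2 to compound 4 (0.44 log units; beyond the scatter) marks the change from pentyloxy to (4-ethoxyphenyl)amino in this assay as a loss, whereas a 3.6-fold lower number from compound 1 to compound 4 (0.56 log units; beyond the scatter) marks the change from hydroxy to the same group as a gain. A nitrogen-linked substituent on this carbon therefore gives a measurable number, and compound 4 ranks behind the pentyl ether of compound 2 but ahead of the hydroxy compound 1; compound 3, reported as not active, gives no number for a step to the arylamine. No evidence is available on what underlies these differences.

Compound 4 changes both the linking atom and the chain, so pentylamino or phenoxy would be needed to separate the two. From the compounds shown here alone, whether the ethoxy group matters remains open without the unsubstituted phenylamino analogue.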